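Shortening the Ether Chain on Compound 1

The compounds below may be only part of what the source reports. "The series", "measured", "known", "first", "only" and "open" are said of these compounds alone.

Three related compounds have been measured in an ADME assay; a higher number here means that the compound lasts longer, a lower number that the compound disappears faster. Compound 1, with the structure `COCOCCOc1cc(OC)ccc1C[S+]([O-])c1ncccc1C(=O)Nc1ccncc1`, gives a half-life of 2.75 h. This places compound 1 second among the three. Compound 3, with the structure `COc1ccc(C[S+]([O-])c2ncccc2C(=O)Nc2ccncc2)c(OC)c1C`, gives 11.6 h, a longer half-life than compound 1 by a gap that lies beyond the usual scatter. Compound 2, with the structure `COc1cc(C)c(C[S+]([O-])c2ncccc2C(=O)Nc2ccncc2)c(OC)c1`, gives 0.09 h, a much shorter half-life than compound 1, again beyond the scatter. The three differ from one another in several places at once, so none of these gaps can be tied to a single change.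

Compound 4, with the structure `COCOc1cc(OC)ccc1C[S+]([O-])c1ncccc1C(=O)Nc1ccncc1`, differs from compound 1 in one place: methoxy in place of (methoxymethoxy)methyl on a saturated chain carbon bound to an oxygen on an aromatic ring. Within the data shown here, no measured pair shows the effect of such a change, so the expectation rests on compound 1 alone. The step from compound 1 to compound 4 is expected to be small, a 1.1-fold lower number from compound 1 to compound 4 (0.04 log units; within the scatter), with either direction possible. Compound 4 is therefore estimated to give 2.5 h in this assay, within a range from 0.8 h to 8 h.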

Compound 4, half-life: 8.25 h
Compound 4: the middle estimate sits 3.3-fold (0.52 log units) below what was measured; the whole stated range lies below it.
By their numbers in this assay, from the lowest: compound 2; then compound 1; then compounds 4 and 3 (each within the scatter of the next).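

In this assay, replacing the 2-(methoxymethoxy)ethoxy chain of the shared core with methoxymethoxy gives a 3.0-fold higher number from compound 1 to compound 4 (0.48 log units; beyond the scatter). Among these compounds, this is the first comparison here in which only one place changes, so a gap in half-life can now be tied to a single edit: this chain is not a silent part of the molecule, and trimming it pays off. Nothing available here explains why the half-life responds to this change.

Among the compounds shown here, two chains give only one step, so they leave open whether the trend would hold for other groups at this place, such as a longer chain, or whether a chain ending in an amine or a hydroxyl group would behave in the same way. They also leave open whether the same change would have a similar effect on other members of the series.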